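This account rests on a few compounds, and the source may have more. Where it says the series, first, only, none or still open, it means among the compounds named here.

Measured compounds:
- compound 1, `O=C(N/N=C/c1ccccc1)c1cccnc1Nc1cccc(C(F)(F)F)c1`, 60.4%
- compound 2, `O=C(N/N=C/c1ccc(O)c(O)c1)c1cccnc1Nc1cccc(C(F)(F)F)c1`, 51.4%
- compound 3, `COc1ccc(/C=N/NC(=O)c2cccnc2Nc2cccc(C(F)(F)F)c2)c(OC)c1`, 37.8%

In a functional assay on the whole organism (strain Wistar) for inhibition, with Rattus norvegicus as the target, read by paw edema, with a stated time of 30 min, at a dose of 10 mg/kg by the intraperitoneal route (a lower number here means less inhibition, a higher number more inhibition at the dose given (going by the name of the read-out)), compound 3 gives the lowest of the three numbers. Its nearest neighbour is compound 2, and the step of a number 13.6 percentage points lower from compound 2 to compound 3 (beyond the scatter) lies beyond the scatter; the furthest is compound 1, with a number 22.6 percentage points lower from compound 1 to compound 3 (beyond the scatter) also beyond the scatter. Compound 4, `O=C(N/N=C/c1ccncc1)c1cccnc1Nc1cccc(C(F)(F)F)c1`, is not yet measured. It differs from compound 3 in one place: pyridin-4-yl in place of 2,4-dimethoxyphenyl on a carbon with a double bond to nitrogen.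

Among the compounds with values here, two measured steps bear on this change. Both alter the same ring on the carbon with a double bond to nitrogen. Compound 1, with an unsubstituted phenyl there, stands highest, and the steps of a number 9 percentage points lower from compound 1 to compound 2 (within the scatter) and a number 22.6 percentage points lower from compound 1 to compound 3 (beyond the scatter) show that adding oxygen substituents to that ring did not raise the read-out. Within the data shown here, removing the two methoxy groups and placing a pyridin-4-yl in their stead therefore seems more likely to move the number back toward compound 1 than further down, though no measured step tests a ring nitrogen here, so the expected size is uncertain. Compound 4 is expected to rise by a number 12.2 percentage points higher from compound 3 to compound 4 (beyond the scatter), to an estimated 50% with a range from 36% to 64%.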

Compound 4, a percentage reported as inhibition, in the whole organism at one dose (the size of the read-out at that dose, not a potency): 68.1%
Compound 4: the middle estimate sits 18.1 percentage points below what was measured, and the stated range ends below it.
By their numbers in this assay, from the lowest: compound 3; then compounds 2, 1 and 4 (each within the scatter of the next, the first and the last beyond it).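

In this assay, the first ring nitrogen on the carbon with a double bond to nitrogen is tested, and the pyridin-4-yl ring gives a number 30.3 percentage points higher from compound 3 to compound 4 (beyond the scatter) and a number 16.7 percentage points higher from compound 2 to compound 4 (beyond the scatter). The step against the plain phenyl ring is a number 7.7 percentage points higher from compound 1 to compound 4 (within the scatter), so a ring nitrogen cannot be told apart from phenyl here, yet compound 4 stands clear of both oxygen-bearing compounds, whereas compound 1 stands clear only of compound 3. Nothing measured on these compounds accounts for these differences.

Whether the ring nitrogen must sit where it does in pyridin-4-yl stays open, since pyridin-2-yl and pyridin-3-yl rings are not among the compounds shown. Also open, on these data alone, is how an amine or a carboxylic acid on this ring would read, and all these numbers come from a single dose, so they say nothing about potency.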